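The source may report more compounds than this note shows. Statements on the series, on what has been measured and on what is new or still open speak of the compounds shown alone.

Measured in a functional assay on MCF7 cells (Homo sapiens) for antiproliferative activity, read by MTT assay, with a stated time of 48 h; on this read-out lower numbers stand for stronger inhibition and higher numbers for weaker inhibition:
- Compound 1 `O=[N+]([O-])c1cc(C(F)(F)F)cc([N+](=O)[O-])c1Oc1ccc(Cl)cc1/C=N\OCc1ccccc1F`: 1110 nM
- Compound 2 `O=[N+]([O-])c1cc(C(F)(F)F)cc([N+](=O)[O-])c1Oc1ccc(Br)cc1/C=N\OCc1ccccc1F`: 1120 nM
- Compound 3 `O=[N+]([O-])c1cc(C(F)(F)F)cc([N+](=O)[O-])c1Oc1ccc(Br)cc1/C=N\OCc1ccc(Cl)cc1Cl`: 1340 nM

In this assay, compound 2 gives 1120 nM and stands within the scatter of both compounds it connects to. The two measured steps are a 1.0-fold higher number from compound 1 to compound 2 (0.00 log units; within the scatter) and a 1.2-fold higher number from compound 2 to compound 3 (0.08 log units; within the scatter).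

Compound 4 `O=[N+]([O-])c1cc(C(F)(F)F)cc([N+](=O)[O-])c1Oc1c(Br)cc(Br)cc1/C=N\OCc1ccccc1F` departs from compound 2 by a single change, (bromo in place of hydrogen on an aromatic carbon), which is bromo in place of hydrogen on an aromatic carbon. Among the compounds with values here, no measured pair shows this kind of addition. The closest evidence is the exchange of one halogen for another on the same ring, a 1.0-fold higher number from compound 1 to compound 2 (0.00 log units; within the scatter). The change at the far end of the molecule, a 1.2-fold higher number from compound 2 to compound 3 (0.08 log units; within the scatter), bears on it only loosely. Both steps are small, so no shift beyond the scatter is expected in this assay, although the untested addition leaves the range wide in either direction. The expected step is a 1.1-fold higher number from compound 2 to compound 4 (0.03 log units; within the scatter). For compound 4 the estimated value is 1200 nM, with an expected range from 500 nM to 3000 nM.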

Compound 4, half-maximal inhibitory concentration: 880 nM
Compound 4: the middle estimate sits 1.4-fold (0.13 log units) above what was measured, and the stated range covers the measured number.
By their numbers in this assay, from the lowest: compounds 4, 1, 2 and 3 (each within the scatter of the next).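

In this assay, within the data shown here, a bromo placed on the aromatic carbon that carries only hydrogen in the earlier compounds, ortho to a large group and meta to a bromo group, gives a 1.3-fold lower number from compound 2 to compound 4 (0.10 log units; within the scatter). The earlier steps shown here exchanged one halogen for another or altered the far end of the molecule, whereas this one shows that the ring can carry an added bromo at this position with no shift beyond the scatter. No measurement shown here offers an explanation for this result.

The compounds shown leave open whether an amine, a methoxy group or a carboxylic acid on this same carbon would also stay within the scatter of compound 2. They also leave open whether the added bromo would give a similar step alongside the 2,4-dichlorophenyl of compound 3.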